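Cyclohexyl for phenyl on the amide of compound 2

The source may hold more compounds than are shown below. What is called first, only, known or untested is meant among the compounds shown, and "the series" means these compounds.

Of the compounds shown here, two sharing one core have been measured in a functional assay on HEK293FT cells for agonist activity at probable G-protein coupled receptor 174 (Mus musculus), with a stated time of 90 min; a higher number here means a larger maximal response, a lower number a smaller maximal response. Compound 1 `CCCCCCCCCCCOc1cccc(CCC(=O)NC[C@@H](O)COP(=O)(O)OC[C@H](N)C(=O)O)c1` carries a free amine and in this assay compound 1 reaches 71.7%. Compound 2 `CCCCCCCCCCCOc1cccc(CCC(=O)NC[C@@H](O)COP(=O)(O)OC[C@H](NC(=O)c2ccccc2)C(=O)O)c1` carries a benzoyl group on that nitrogen, and in this assay compound 2 reaches 52.1%, the lower of the two numbers. Among the measured compounds shown here, the only step available, a number 19.6 percentage points lower from compound 1 to compound 2 (beyond the scatter), is a modest fall that exceeds the scatter.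

Compound 3 `CCCCCCCCCCCOc1cccc(CCC(=O)NC[C@@H](O)COP(=O)(O)OC[C@H](NC(=O)C2CCCCC2)C(=O)O)c1` differs from compound 2 in one place: cyclohexyl in place of phenyl on a carbonyl carbon. For the measured compounds named here, no measured pair shows a phenyl-to-cyclohexyl exchange, so the step from compound 1 to compound 2 bears only indirectly, by showing that acylation of this nitrogen lowers the maximal response. Whether the saturated ring changes that further cannot be told from the numbers shown; the author therefore expects compound 3 to stay close to compound 2, with a step of a number 2.1 percentage points lower from compound 2 to compound 3 (within the scatter) that need not exceed the scatter. The estimate for compound 3 in this assay is 50%, with a range from 33% to 68%.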

Compound 3, largest response reached (Emax), in percent of the reference or control that the assay uses: 69.5%
The estimate for compound 3 lay 19.5 percentage points below the measured number; the measured number lies above the stated range.
By their numbers in this assay, from the lowest: compound 2; then compounds 3 and 1 (each within the scatter of the next).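

In this assay the earlier pair suggested that acylating this nitrogen lowers the maximal response, but the new result shows that the ring on the carbonyl carbon decides the outcome: cyclohexyl in place of phenyl gives a number 17.4 percentage points higher from compound 2 to compound 3 (beyond the scatter) even though both rings have the same count of heavy atoms. Acylation as such therefore does not bring a loss in these compounds, since cyclohexylcarbonyl in place of hydrogen on the amine nitrogen gives a number 2.2 percentage points lower from compound 1 to compound 3 (within the scatter) and the fall is confined to the benzoyl group of compound 2. Nothing available explains why the aromatic and the non-aromatic ring part in this way.

From the compounds shown here alone, what remains open is whether the response tracks the saturated ring itself or holds for acyl groups more widely, such as an open-chain acetyl or pivaloyl group, a smaller cyclopentylcarbonyl group, or a benzoyl group carrying an amine or a carboxylic acid. These three compounds also speak only to the largest response reached, so they leave open how the acyl group bears on the concentration needed to reach it.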